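A Chloro Substituent Tested on Two Benzyl-Purine Cores

A few compounds are considered here, and "the series" means these few. Any claim that something is new, unique, unknown or untested is made for them only; others in the source may bear on it.

Three compounds were examined in a functional assay on NCI/ADR-RES cells (Homo sapiens) for cytotoxicity, read by sulforhodamine B assay, with a stated time of 48 h; a higher number here means a weaker inhibitor of growth, a lower number a stronger inhibitor of growth. Compound 1 `ClCc1ccccc1Cn1cnc2c(Cl)nc(Cl)nc21` gives 3020 nM in this assay. Compound 2 `ClCc1ccccc1Cn1cnc2c(Cl)ncnc21` gives 4670 nM, and compound 3 `ClCc1cccc(Cn2cnc3ncnc(Cl)c32)c1` gives 9770 nM, the highest number of the three, so that among the measured compounds it is the weakest inhibitor of growth. Compound 2 and compound 3 contain the same atoms joined differently; the difference between the two cores is not broken down here.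

Compound 1 and compound 2 differ in one place: chloro in place of hydrogen on an aromatic carbon. In this assay the step is a 1.5-fold lower number from compound 2 to compound 1 (0.19 log units; within the scatter), so the chloro substituent changed little in that pair.

Compound 4 `ClCc1cccc(Cn2cnc3nc(Cl)nc(Cl)c32)c1` has not yet been measured. It differs from compound 3 by chloro in place of hydrogen on an aromatic carbon, the same change that turns compound 2 into compound 1, in the same surroundings, and it occurs twice among the compounds shown. Within the data shown here, since the only earlier example of this change gave a 1.5-fold lower number from compound 2 to compound 1 (0.19 log units; within the scatter), a small step is expected from compound 3 to compound 4 as well, namely a 1.4-fold lower number from compound 3 to compound 4 (0.14 log units; within the scatter). On this basis compound 4 is estimated at 7000 nM in this assay, with a range from 3500 nM to 14000 nM expected for repeated measurements.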

Compound 4, concentration for total growth inhibition: 3090 nM
The estimate for compound 4 lay 2.3-fold (0.36 log units) above the measured number; measured number below the stated range.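

In this assay, chloro in place of hydrogen on an aromatic carbon gives a 3.2-fold lower number from compound 3 to compound 4 (0.50 log units; beyond the scatter), a step in the same direction as the one seen earlier on the other core, and the two steps cannot be told apart: the same change on two cores in this assay, a 1.5-fold lower number (0.19 log units; within the scatter) from compound 2 to compound 1 and a 3.2-fold lower number (0.50 log units; beyond the scatter) from compound 3 to compound 4, 2.0-fold (0.31 log units) apart, within the scatter of two such steps. The change therefore carried over from the core of compound 2 to the core of compound 3 in direction, and the numbers give no firm ground for saying that the core alters the size of the step. Among these compounds, this does not fix a size for the change, since only two pairs are available and only one of the two steps lies beyond the scatter on its own, nor does it show that the same direction would hold on any further core.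

The compounds shown leave open what other groups would do on this aromatic carbon, between two ring nitrogen atoms, for instance whether an amine or a methoxy group would move the number as chloro does. They also leave open whether the step seen in these cells would appear in other cell lines, as all the numbers here come from a single assay.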